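Taking one methyl off a growth inhibitor

The source may report more compounds than this note shows. Statements on the series, on what has been measured and on what is new or still open speak of the compounds shown alone.

Measured so far in a functional assay on PC-3 cells (Homo sapiens); on this read-out lower numbers stand for stronger inhibition of growth and higher numbers for weaker inhibition of growth:
compound 1 `COc1cccc(-c2cc(=O)c3ccc(C)nc3[nH]2)c1`: 33.1 nM
compound 2 `COc1cccc(-c2cc(O)c3cc(C)cnc3n2)c1`: 42.7 nM

These two compounds are all that has been measured, and they cannot be told apart on these numbers. Compound 2, at 42.7 nM, lies within the usual scatter of compound 1, at 33.1 nM. Within the data shown here, both carry a methyl on the shared core, though not in the same place, and no pair of measured compounds differs in one place alone.

The next compound, compound 3 `COc1cccc(-c2cc(O)c3cccnc3n2)c1`, has hydrogen in place of methyl on an aromatic carbon of compound 2: hydrogen in place of methyl on an aromatic carbon. This carbon belongs to a six-membered aromatic ring with 1 nitrogen, part of a fused or bridged system of two rings.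

Among the measured compounds shown here, no measured compound lacks a methyl, so the data offer no direct guide to this change, and any forecast is uncertain. A modest loss of growth inhibition in this assay is expected, perhaps just beyond the scatter. The expected size of the step is a 2.1-fold higher number from compound 2 to compound 3 (0.32 log units; beyond the scatter). For compound 3 the estimated value is 90 nM, with an expected range of 25 nM to 350 nM.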

Compound 3, concentration for 50% growth inhibition: 93.3 nM
For compound 3 the middle estimate is 1.0-fold (0.02 log units) below the measured one, within the range that was stated.
By their numbers in this assay, from the lowest: compounds 1 and 2 (each within the scatter of the next); then compound 3.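

Among these compounds, this is the first pair that differs in one place alone, so the methyl on this aromatic carbon, two atoms from the ring nitrogen, can now be judged by itself. In this assay hydrogen in place of that methyl gives a 2.2-fold higher number from compound 2 to compound 3 (0.34 log units; beyond the scatter) and so a modest loss of growth inhibition, which shows that this methyl contributes to growth inhibition in this pair, though not by much. Nothing shown here accounts for the size of this step or tells what the methyl does at this position.

What the compounds shown leave open is whether a longer chain such as ethyl, a halogen such as chlorine, or a methoxy group on the same carbon would match the methyl, improve on it or fall short of it. On these data alone, it also remains open whether the methyl in compound 1, which sits elsewhere on the shared core, matters to a similar degree, and whether the step seen here would hold with a different group on the outer methoxy-bearing ring.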